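Terminal aryl variation on the shared core: compound 4

The source may hold more compounds than are shown below. What is called first, only, known or untested is meant among the compounds shown, and "the series" means these compounds.

Compound 3 `CSc1ccc(CCCCCCC(=O)c2ncc(-c3ccccn3)o2)cc1` gives 2.5 nM in an assay for inhibition of Fatty-acid amide hydrolase 1 (Rattus norvegicus) (on this read-out higher numbers stand for weaker inhibition and lower numbers for stronger inhibition), the second highest of the three numbers; compound 1 `O=C(CCCCCCc1cccc(Cl)c1Cl)c1ncc(-c2ccccn2)o1` gives 0.9 nM and compound 2 `Nc1cccc(CCCCCCC(=O)c2ncc(-c3ccccn3)o2)c1` gives 30 nM. The steps of a 2.8-fold higher number from compound 1 to compound 3 (0.44 log units; beyond the scatter) and a 12-fold lower number from compound 2 to compound 3 (1.08 log units; beyond the scatter) show that the aryl group at this chain position moves the read-out well beyond the scatter, as does a 33-fold higher number from compound 1 to compound 2 (1.52 log units; beyond the scatter). Compound 4 `O=C(CCCCCSc1ccccc1)c1ncc(-c2ccccn2)o1` differs from compound 3 by phenylsulfanyl in place of 4-(methylsulfanyl)benzyl on a saturated chain carbon, five bonds along the chain from a carbonyl carbon. Among the compounds with values here, no measured step replaces a chain carbon with sulfur or removes the 4-(methylsulfanyl) substituent, so the aryl exchanges bear only indirectly. Because the steps of a 2.8-fold higher number from compound 1 to compound 3 (0.44 log units; beyond the scatter) and a 33-fold higher number from compound 1 to compound 2 (1.52 log units; beyond the scatter) both raised the number, a modest weakening is expected for compound 4, amounting to a 2.4-fold higher number from compound 3 to compound 4 (0.38 log units; beyond the scatter). Compound 4 is estimated at 6 nM, range 2 nM to 20 nM.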

Compound 4, inhibition constant: 3 nM
Compound 4: middle estimate off by 2.0-fold (0.30 log units), on the high side; measured number inside the range.
By their numbers in this assay, from the lowest: compound 1; then compounds 3 and 4 (each within the scatter of the next); then compound 2.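

In this assay, phenylsulfanyl in place of 4-(methylsulfanyl)benzyl gives a 1.2-fold higher number from compound 3 to compound 4 (0.08 log units; within the scatter), so unlike the earlier aryl exchanges, this change at the chain end stays within the scatter. Within the data shown here, the other two new steps lie beyond it, a 10-fold lower number from compound 2 to compound 4 (1.00 log units; beyond the scatter) and a 3.3-fold higher number from compound 1 to compound 4 (0.52 log units; beyond the scatter), matching the earlier steps to compound 3 in direction. No evidence in hand accounts for this result.

Sulfur entering the chain and loss of the 4-(methylsulfanyl) substituent arrive in one step, so their separate contributions remain open. A 2,3-dichlorophenylsulfanyl end or a longer chain carrying phenylsulfanyl would extend the comparison.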